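One Carbon Longer on the Alkyne Chain: Compound 3

The source may report more compounds than this note shows. Statements on the series, on what has been measured and on what is new or still open speak of the compounds shown alone.

Compound 1, `O=c1nc2occc2cn1COCCO`, and compound 2, `CCCCC#Cc1cc2cn(COCCO)c(=O)nc2o1`, share one core and differ at a single aromatic carbon, where compound 2 carries a hex-1-yn-1-yl group in place of hydrogen. In a functional assay on HEL cells (Homo sapiens), read by microscopy (a higher number here means that more compound is tolerated, a lower number that less compound is tolerated), compound 1 gives only a limit, > 400000 nM. In this assay compound 2 also gives only a limit, > 100000 nM. The step that the two limits leave unreadable from compound 1 to compound 2 therefore has no readable size, because both of its ends are limits, the limit of > 400000 nM in this assay, at which 1 of the 2 values shown sits, and (the limit of > 100000 nM in this assay, at which 1 of the 2 values shown sits). Compound 2 thus stands at a limit in this assay, with no number of its own to place it against compound 1.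

Compound 3, `CCCCCC#Cc1cc2cn(COCCO)c(=O)nc2o1`, differs from compound 2 by methyl in place of hydrogen on a saturated chain carbon, four bonds along the chain from a triple-bonded carbon. Within the data shown here, the only measured step that bears on this change is a step that the two limits leave unreadable from compound 1 to compound 2, and its size cannot be read, so there is no measured basis for expecting a step beyond the usual scatter in this assay. The step of a number no higher from compound 2 to compound 3 (the limit leaves the size open) is therefore expected to be small. Compound 3 is estimated at 100000 nM in this assay, with a range of 50000 nM to 400000 nM, and most likely again only a limit.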

Compound 3, minimum cytotoxic concentration: >= 100000 nM
Compound 3 was reported as a limit; the forecaster's own chance of this, stated with the estimate: 85%; the middle value sits exactly at the limit.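

Compound 3 is reported only as a limit in this assay, as are compound 1 and compound 2, so none of the steps among these three compounds can be read. The compounds shown leave open what concentration of each is first cytotoxic, and whether lengthening the alkyne chain from hex-1-yn-1-yl to hept-1-yn-1-yl changes it.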